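Compound 2 and the step to compound 3 in microsomal clearance

The source may hold more compounds than are shown below. What is called first, only, known or untested is meant among the compounds shown, and "the series" means these compounds.

For the measured compounds named here, compound 2 `CC(C)c1noc(N2CCC(Oc3cc(N4CCc5cc(N6CCOCC6=O)ccc54)ncn3)CC2)n1` gives 46 mL.min-1.g-1 in an ADME assay on microsomes from liver (Rattus norvegicus) for metabolic stability, read by LC-MS, using NADPH, with a stated time of 30 min, tested at 1 uM (a lower number here means slower removal, a higher number faster removal of the compound), the higher of the two numbers measured so far. Going by the values given here, compound 1 `CC(=O)N(C)c1ccc2c(c1)CCN2c1cc(OC2CCN(c3nc(C(C)C)no3)CC2)ncn1` gives 17 mL.min-1.g-1 in this assay, and the single measured step, a 2.7-fold higher number from compound 1 to compound 2 (0.43 log units; beyond the scatter), concerns a change at the same aromatic carbon but of a different kind. Compound 3 `CC(C)c1noc(N2CCC(Oc3cc(N4CCc5cc(N6CCC(O)CC6=O)ccc54)ncn3)CC2)n1` differs from compound 2 in one place: 4-hydroxy-2-oxopiperidin-1-yl in place of 3-oxomorpholin-4-yl on an aromatic carbon. Among the compounds with values here, no measured step covers 4-hydroxy-2-oxopiperidin-1-yl in place of 3-oxomorpholin-4-yl, so the expectation rests on the number for compound 2 alone and on the modest size of the one step that was seen. Compound 3 is therefore expected to give a step of a 1.3-fold lower number from compound 2 to compound 3 (0.12 log units; within the scatter), which would stay within the scatter. Compound 3 is estimated at 35 mL.min-1.g-1, with a range from 15 mL.min-1.g-1 to 80 mL.min-1.g-1.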

Compound 3, intrinsic clearance in microsomes in the Rattus norvegicus assay: 13 mL.min-1.g-1
For compound 3 the middle estimate is 2.7-fold (0.43 log units) above the measured one, outside the stated range (below it).
By their numbers in the Rattus norvegicus assay, from the lowest: compounds 3 and 1 (each within the scatter of the next); then compound 2.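

In the Rattus norvegicus assay the lactam ring on this aromatic carbon proves sensitive to a small exchange: 4-hydroxy-2-oxopiperidin-1-yl in place of 3-oxomorpholin-4-yl brings a 3.5-fold lower number from compound 2 to compound 3 (0.55 log units; beyond the scatter), whereas the same group in place of acetyl(methyl)amino brings only a 1.3-fold lower number from compound 1 to compound 3 (0.12 log units; within the scatter), so a group at this place can return the number to the level of compound 1. In a physicochemical assay for lipophilicity, measured as octanol-water partition, at pH 7.4 (on this read-out higher numbers stand for higher lipophilicity and lower numbers for lower lipophilicity), compound 2 gives 3.1 and compound 3 gives 2.8, a step of a number 0.30 log units lower from compound 2 to compound 3 (within the scatter), so the two compounds separate on removal but not on this read-out. Nothing available explains the step in removal.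

Open, going by these compounds, is whether the hydroxy group or the loss of the ring oxygen carries this step; the two change together in compound 3. Also open, on these data alone, is how a piperidinone ring bearing an amine or a carboxylic acid instead of the hydroxy group would read.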